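This account rests on a few compounds, and the source may have more. Where it says the series, first, only, none or still open, it means among the compounds named here.

In a functional assay on MCF7 cells (Homo sapiens) for antiproliferative activity, read by MTT assay (a lower number here means a stronger inhibitor, a higher number a weaker inhibitor), compound 1 `COc1cc2c(Oc3ccc(NC(=O)Nc4ccccc4C(F)(F)F)cc3)ccnc2cc1OCCCCCCC(=O)NO` gives 1080 nM and compound 2 `COc1cc2c(Oc3ccc(NC(=O)Nc4ccc(C)cc4C)cc3)ccnc2cc1OCCCCCCC(=O)NO` gives 3430 nM, so compound 2 holds the higher, weaker number of the two. Compound 3 `COc1cc2c(Oc3ccc(NC(=O)NNC(=O)c4ccccc4F)cc3)ccnc2cc1OCCCCCCC(=O)NO` changes the same part of the molecule: ((2-fluorophenyl)carbonyl)amino in place of 2,4-dimethylphenyl on an amide-type nitrogen. Here ((2-fluorophenyl)carbonyl)amino takes the place of 2,4-dimethylphenyl on an amide-type nitrogen. Among the measured compounds shown here, only one measured step bears on this change: a 3.2-fold higher number from compound 1 to compound 2 (0.50 log units; beyond the scatter). It is modest but beyond the scatter, and it also exchanges the group on that amide-type nitrogen. That step replaced one substituted phenyl group with another, whereas the new group also brings a carbonyl, so it suggests a size but no direction. No step beyond the scatter is therefore expected in this assay, although a similar step either way is possible. As a number, the expected change is a 1.4-fold lower number from compound 2 to compound 3 (0.14 log units; within the scatter). Compound 3 is estimated at 2500 nM, with an expected range of 700 nM to 9000 nM.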

Compound 3, half-maximal inhibitory concentration: 3600 nM
Beside the measured number, compound 3's estimate is 1.4-fold (0.16 log units) below it; low and high end bracket the measured number.
By their numbers in this assay, from the lowest: compound 1; then compounds 2 and 3 (each within the scatter of the next).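

In this assay, putting ((2-fluorophenyl)carbonyl)amino in place of 2,4-dimethylphenyl on the amide-type nitrogen gives a 1.0-fold higher number from compound 2 to compound 3 (0.02 log units; within the scatter), so the longer group with its added carbonyl leaves the reading at this position unchanged within the scatter. Measured against the 2-(trifluoromethyl)phenyl group, the same new group gives a 3.3-fold higher number from compound 1 to compound 3 (0.52 log units; beyond the scatter), which means compound 1 keeps the lowest number of the three, with its steps to both others beyond the scatter. Nothing available explains why these groups rank this way.

As far as these compounds go, it remains open whether the fluorine on compound 3 contributes anything, which a phenylcarbonylamino group without fluorine would test. From the compounds shown here alone, it is equally open whether the trifluoromethyl group of compound 1 gives the lower number on its own, which a plain phenyl or a 2-methylphenyl group on the same nitrogen could help to show.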